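Hydroxy in Place of (Isopropylsulfonyl)amino on a Shared Core

The source may report more compounds than this note shows. Statements on the series, on what has been measured and on what is new or still open speak of the compounds shown alone.

In an assay on isolated protein (Cricetulus griseus) for binding affinity to Alpha-1B adrenergic receptor (Mesocricetus auratus), read by radioligand binding (on this read-out higher numbers stand for weaker inhibition and lower numbers for stronger inhibition), compound 1 `CC(C)S(=O)(=O)Nc1cccc2c1CCCC2c1c[nH]cn1` is known only as a limit, < 10000 nM. Compound 2 `COC(=O)Nc1cccc2c1CCCC2c1c[nH]cn1` gives 10000 nM in this assay. Going by the values given here, the single measured step, a number no lower from compound 1 to compound 2 (the limit leaves the size open), runs from a limit to a number, (the limit of < 10000 nM in this assay, at which 1 of the 2 values shown sits), so its size stays open. Compound 3 `Oc1cccc2c1CCCC2c1c[nH]cn1` differs from compound 1 by hydroxy in place of (isopropylsulfonyl)amino on an aromatic carbon. Among the compounds with values here, no measured step covers a hydroxy entering, so only the range of the measured values anchors the expectation. Compound 3 is therefore expected at 5000 nM, between 800 nM and 10000 nM, with an estimated step that the limit leaves unreadable from compound 1 to compound 3 that stays within the scatter.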

Compound 3, inhibition constant: 145 nM
Compound 3: the middle estimate sits 34-fold (1.54 log units) above what was measured; the whole stated range lies above it.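

Putting hydroxy in place of (methoxycarbonyl)amino on this aromatic carbon gives a 69-fold lower number from compound 2 to compound 3 (1.84 log units; beyond the scatter) in this assay. Going by these compounds alone, this is the first readable sign that the group at this position can change inhibition strongly, and the smaller group here gives the stronger inhibition. The step from compound 1 to compound 3 cannot be read, because compound 1 is known only as a limit: the limit of < 10000 nM in this assay, at which 1 of the 3 values shown sits.

The compounds shown leave open how a methoxy group, an amine or a plain hydrogen on this carbon would compare with hydroxy. They also leave open whether hydroxy would give a similar step on another aromatic carbon of the shared core.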